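Amide-side variation and cytotoxicity in the shared core

A few compounds are considered here, and "the series" means these few. Any claim that something is new, unique, unknown or untested is made for them only; others in the source may bear on it.

Values in an ADME assay on HepG2 2.2.15 cells (Homo sapiens) for cytotoxicity, read by MTT assay, with stated times of 48 h and 9 days (a lower number here means that less compound is tolerated, a higher number that more compound is tolerated), for the two measured compounds:
compound 1 `COc1ccc2c(=O)c(/C=C/C(=O)NCc3ccccc3F)coc2c1`: 146000 nM
compound 2 `COc1ccc2c(=O)c(/C=C/C(=O)Nc3ccc(F)cc3)coc2c1`: 743000 nM

Going by the values given here, compound 2 stands at the higher of the two numbers; the gap to compound 1 is the only measured step, a 5.1-fold higher number from compound 1 to compound 2 (0.71 log units; beyond the scatter), which exchanges the whole group on the amide-type nitrogen rather than a single substituent on it.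

Compound 3 `COc1ccc2c(=O)c(/C=C/C(=O)Nc3ccc(C)cc3)coc2c1` differs from compound 2 by methyl in place of fluoro on an aromatic carbon. Among the compounds with values here, no measured step swaps one substituent for another on this ring, so nothing in the data speaks directly to the change. Within the data shown here, the one step available changed benzyl for phenyl together with the substituent and still moved the number only modestly, so a substituent swap alone is expected to stay within the scatter.

Compound 3 is therefore estimated at 700000 nM in this assay, in the range 300000 nM to 1500000 nM, meaning an expected step of a 1.1-fold lower number from compound 2 to compound 3 (0.03 log units; within the scatter).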

Compound 3, half-maximal cytotoxic concentration: 979000 nM
For compound 3 the middle estimate is 1.4-fold (0.15 log units) below the measured one; the range from low to high includes it.
By their numbers in this assay, from the lowest: compound 1; then compounds 2 and 3 (each within the scatter of the next).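

In this assay, going by these compounds alone, the first direct swap on this ring, 4-fluorophenyl to 4-methylphenyl, gives a 1.3-fold higher number from compound 2 to compound 3 (0.12 log units; within the scatter) and so leaves compounds 2 and 3 indistinguishable at this position. The gap to the 2-fluorobenzyl group of compound 1 holds for the methyl member as well, with a 6.7-fold higher number from compound 1 to compound 3 (0.83 log units; beyond the scatter) on record, so it is shared by both 4-substituted phenyl amides shown. Nothing available accounts for either step.

Compound 1 differs from both phenyl amides in the linking carbon and in the fluoro placement together, so the shares of these two changes in the gap remain unseparated. Also open, from the compounds shown here alone, is whether a carboxylic acid or an amine on the phenyl ring, or a longer chain between the amide nitrogen and the ring, would leave the number unchanged.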